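The source may hold more compounds than are shown below. What is called first, only, known or untested is meant among the compounds shown, and "the series" means these compounds.

- Compound 1 `O=C(O)c1cc(-n2cccc2)ccc1O`: 50 mg/kg
- Compound 2 `O=C(O)c1cc(-c2c[nH]cn2)ccc1O`: 100 mg/kg

Going by the values given here, in a functional assay on the whole organism for inhibition, with Rattus norvegicus as the target, read by paw edema (a higher number here means that more compound is needed for the effect, a lower number that less compound is needed), compound 2 gives 100 mg/kg, which puts it level, within the scatter, with the only other compound measured so far. Compound 3 `O=C(O)c1cc(-c2cc[nH]n2)ccc1O` has not yet been measured. It keeps the core of compound 2 and alters one group: 1H-pyrazol-3-yl in place of 1H-imidazol-4-yl on an aromatic carbon. The 1H-pyrazol-3-yl group stands in place of 1H-imidazol-4-yl, on an aromatic carbon meta to the carboxy group and para to the hydroxy group. Among the compounds with values here, only one measured step bears on this, a 2.0-fold higher number from compound 1 to compound 2 (0.30 log units; within the scatter), which also swaps one five-membered aromatic ring for another on that carbon. Within the data shown here, no measured compound carries the new group, so the expectation stays loose. The step expected here, a 1.3-fold lower number from compound 2 to compound 3 (0.10 log units; within the scatter), stays within the scatter, with no clear direction. For compound 3 the estimated value is 80 mg/kg, with an expected range from 30 mg/kg to 200 mg/kg.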

Compound 3, dose for half-maximal effect: > 250 mg/kg
Compound 3 ended at the assay's limit; the forecaster's own chance of this, stated with the estimate: 5%; middle value at least 3.1-fold (0.49 log units) from the limit.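

In this assay compound 3 stands at a limit and not at a number: the limit of > 250 mg/kg in this assay, at which 1 of the 3 values shown sits. Even so, the arrangement of the ring atoms matters here: 1H-pyrazol-3-yl in place of 1H-imidazol-4-yl gives an at least 2.5-fold higher number from compound 2 to compound 3 (0.39 log units; beyond the scatter), although the two groups have the same atoms, joined differently. Replacing 1H-pyrrol-1-yl with the same group gives an at least 5.0-fold higher number from compound 1 to compound 3 (0.69 log units; beyond the scatter), whereas the earlier swap gave only a 2.0-fold higher number from compound 1 to compound 2 (0.30 log units; within the scatter), so this aromatic carbon, meta to the carboxy group and para to the hydroxy group, does respond to which five-membered ring it carries.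

The compounds shown leave open how far compound 3 lies past the limit, and so the true size of both new steps. They also leave open whether an amine added to the 1H-pyrazol-3-yl group would bring the number back down.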